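Swapping a Fluorohydroxyphenyl Ring for Pyridinyl

This account rests on a few compounds, and the source may have more. Where it says the series, first, only, none or still open, it means among the compounds named here.

In a functional assay on PC-3 cells (Homo sapiens) for inhibition (on this read-out higher numbers stand for weaker inhibition and lower numbers for stronger inhibition), compound 2 `Cc1c(C(=O)N/N=C\c2cccc(F)c2O)oc2cccc(O)c12` gives 12700 nM. For the measured compounds named here, compound 1 `Cc1c(C(=O)N/N=C\c2cccc(O)c2O)oc2cccc(O)c12` gives 12200 nM, and the only measured step, a 1.0-fold higher number from compound 1 to compound 2 (0.02 log units; within the scatter), shows that the two numbers cannot be told apart. Compound 3 `Cc1c(C(=O)N/N=C\c2cccnc2)oc2cccc(O)c12` carries pyridin-3-yl in place of 3-fluoro-2-hydroxyphenyl on a carbon with a double bond to nitrogen. Going by the values given here, no measured step tests an exchange of one whole ring for another; the step from compound 1 to compound 2 altered only a substituent on the ring that now leaves. For compound 3 the expected outcome is no step beyond the scatter, with wide uncertainty, a 1.0-fold higher number from compound 2 to compound 3 (0.01 log units; within the scatter). Compound 3 is estimated at 13000 nM, between 4000 nM and 45000 nM.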

Compound 3, half-maximal inhibitory concentration: >= 40000 nM
Compound 3: a limit, no number (the forecaster's own chance of this, stated with the estimate: 20%); middle value at least 3.0-fold (0.48 log units) away from the limit.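

Exchanging the whole ring does what changing a substituent on it did not: in this assay, pyridin-3-yl in place of 3-fluoro-2-hydroxyphenyl gives an at least 3.1-fold higher number from compound 2 to compound 3 (0.49 log units; beyond the scatter), and pyridin-3-yl in place of 2,3-dihydroxyphenyl gives an at least 3.2-fold higher number from compound 1 to compound 3 (0.51 log units; beyond the scatter). Compound 3 reads only as a limit, not as a number: the limit of >= 40000 nM in this assay, at which 1 of the 3 values shown sits. On this carbon with a double bond to nitrogen, replacing the ring therefore counts for more than swapping hydroxy for fluoro on it.

Nothing shown separates the departure of the hydroxy group from the arrival of the ring nitrogen. On these data alone, how a plain phenyl ring or a pyridine ring carrying a hydroxy group would read at this carbon stays open.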